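Amide series on the shared core: extending the aromatic amine

The source may report more compounds than this note shows. Statements on the series, on what has been measured and on what is new or still open speak of the compounds shown alone.

In an assay on CHO cells for displacement of a labelled ligand from adenosine receptor A3 (Homo sapiens) (on this read-out lower numbers stand for stronger inhibition and higher numbers for weaker inhibition), compound 2 `CNc1nc(Cl)nc2c1ncn2[C@@H]1O[C@H](C(=O)NC2CC2)[C@@H](O)[C@H]1O` gives 2.82 nM and has the lowest number of the three measured. Compound 1 `CNc1nc(Cl)nc2c1ncn2[C@@H]1O[C@H](C(=O)N(C)C)[C@@H](O)[C@H]1O` gives 1510 nM and compound 3 `CNc1nc(Cl)nc2c1ncn2[C@@H]1O[C@H](C(=O)N2CCOCC2)[C@@H](O)[C@H]1O` gives 3890 nM; the steps are a 540-fold lower number from compound 1 to compound 2 (2.73 log units; beyond the scatter), a 2.6-fold higher number from compound 1 to compound 3 (0.41 log units; beyond the scatter) and a 1400-fold higher number from compound 2 to compound 3 (3.14 log units; beyond the scatter), all on the carbonyl carbon, which compound 4 keeps as cyclopropylamino.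

Compound 4 `Cc1ccccc1CNc1nc(Cl)nc2c1ncn2[C@@H]1O[C@H](C(=O)NC2CC2)[C@@H](O)[C@H]1O` differs from compound 2 elsewhere: 2-methylphenyl in place of hydrogen on a saturated chain carbon bound to a nitrogen on an aromatic ring. Going by the values given here, no measured step touches the nitrogen on the aromatic ring, so the three steps do not bear on this change, and no step beyond the scatter is expected in this assay. The estimate for compound 4 is 3.5 nM, range 0.7 nM to 18 nM, which means a 1.2-fold higher number from compound 2 to compound 4 (0.09 log units; within the scatter) is expected.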

Compound 4, inhibition constant: 27.5 nM
The estimate for compound 4 lay 7.9-fold (0.90 log units) below the measured number; the measured number lies above the stated range.
By their numbers in this assay, from the lowest: compound 2; then compound 4; then compound 1; then compound 3.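

In this assay, the site on the saturated chain carbon bound to a nitrogen on an aromatic ring proves responsive: 2-methylphenyl in place of hydrogen gives a 9.8-fold higher number from compound 2 to compound 4 (0.99 log units; beyond the scatter) on the cyclopropylamino amide. This step is modest, while replacing cyclopropylamino with morpholin-4-yl on the carbonyl carbon gives a 1400-fold higher number from compound 2 to compound 3 (3.14 log units; beyond the scatter) in the same assay. Nothing shown gives a reason for the rise.

Going by these compounds, whether a plain benzyl group or a 2-phenylethyl chain on that nitrogen would read differently stays open. So does whether 2-methylphenyl would shift the number similarly with dimethylamino on the carbonyl carbon.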